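Trifluoromethyl to methoxy: expecting compound 4

A few compounds are considered here, and "the series" means these few. Any claim that something is new, unique, unknown or untested is made for them only; others in the source may bear on it.

Measured in an ADME assay on a cell-free system (plasma, Homo sapiens) for protein binding; on this read-out higher numbers stand for a larger free fraction and lower numbers for a smaller free fraction:
compound 1 `Cc1c(Cl)nnc2sc(C(=O)NC3CN(c4cc(C(F)(F)F)ncc4Cl)C3)c(N)c12`: 0.019
compound 2 `Cc1c(CF)nnc2sc(C(=O)NC3CN(c4ncc(C(F)(F)F)cn4)C3)c(N)c12`: 0.042
compound 3 `COc1nnc2sc(C(=O)NC3CN(c4ncc(C(F)(F)F)cn4)C3)c(N)c2c1C`: 0.02

In this assay compound 1 gives 0.019, within the scatter of compound 3 at 0.02, while compound 2 shows a clearly higher 0.042. Compound 4 `COc1cc(N2CC(NC(=O)c3sc4nnc(Cl)c(C)c4c3N)C2)c(Cl)cn1` differs from compound 1 in one place: methoxy in place of trifluoromethyl on an aromatic carbon. Among the compounds with values here, the only measured step bringing in methoxy is a 2.1-fold lower number from compound 2 to compound 3 (0.32 log units; beyond the scatter), but the group leaving there is fluoromethyl, at another place, so it bears only weakly on this exchange. Within the data shown here, no measured step covers the exchange itself, and its direction stays uncertain. The expected change is small, an estimated 1.4-fold higher number from compound 1 to compound 4 (0.14 log units; within the scatter). The estimate for compound 4 is 0.026. The expected range for compound 4 runs from 0.013 to 0.05.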

Compound 4, unbound fraction: < 0.001
Compound 4 gave a limit, no number; the forecaster's own chance of this, stated with the estimate: 2%; middle value at least 26-fold (1.41 log units) from the limit.
By their numbers in this assay, from the lowest: compounds 1 and 3 (each within the scatter of the next); then compound 2. At a limit, below all of these: compound 4.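

In this assay, methoxy in place of trifluoromethyl next to the ring nitrogen gives an at least 19-fold lower number from compound 1 to compound 4 (1.27 log units; beyond the scatter), so this exchange at this position is far from neutral for the free fraction. Within the data shown here, the only earlier step bringing in methoxy, at another place and with fluoromethyl leaving, was modest: a 2.1-fold lower number from compound 2 to compound 3 (0.32 log units; beyond the scatter). The value of compound 4 is a limit of this assay and not a number: the limit of < 0.001 in this assay, at which 1 of the 4 values shown sits.

From the compounds shown here alone, how large the step truly is stays open. So does whether a small amine or a plain methyl at this place would behave like methoxy or like trifluoromethyl.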